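Working notes: cytotoxicity across an aryl-substituted series

A few compounds are considered here, and "the series" means these few. Any claim that something is new, unique, unknown or untested is made for them only; others in the source may bear on it.

The series keeps one shared core and varies the aryl group attached to it. Compound 1 is `N#Cc1c(-c2ccc(Cl)cc2)c(C#N)c(=O)n(/N=C/c2cn(-c3ccccc3)nc2-c2ccccc2)c1N`. Compound 2 is `COc1ccc(-c2c(C#N)c(N)n(/N=C/c3cn(-c4ccccc4)nc3-c3ccccc3)c(=O)c2C#N)cc1`. Compound 3 is `N#Cc1c(-c2ccc([N+](=O)[O-])cc2)c(C#N)c(=O)n(/N=C/c2cn(-c3ccccc3)nc2-c2ccccc2)c1N`. In an ADME assay on HeLa cells (Homo sapiens) for cytotoxicity, read by MTT assay (a lower number here means a stronger inhibitor, a higher number a weaker inhibitor), compound 1 returns only a limit of the assay, > 200 ug/mL. Compound 2 likewise gives only a limit in this assay, > 200 ug/mL. Compound 3 also comes back as a limit in this assay, > 200 ug/mL. Compound 3 therefore stands at the assay limit together with the two other values shown, as the limit of > 200 ug/mL in this assay, at which 3 of the 3 values shown sit, records. The steps a step that the two limits leave unreadable from compound 1 to compound 2, a step that the two limits leave unreadable from compound 1 to compound 3 and a step that the two limits leave unreadable from compound 2 to compound 3 are all unreadable: both ends of each sit at the limit.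

Compound 4, not yet measured, is `N#Cc1c(-c2ccccc2C(F)(F)F)c(C#N)c(=O)n(/N=C/c2cn(-c3ccccc3)nc2-c2ccccc2)c1N`. It differs from compound 3 by 2-(trifluoromethyl)phenyl in place of 4-nitrophenyl on an aromatic carbon. All three measured steps bear on this change in that each swaps the group on the same aromatic carbon of the shared core, yet none yielded a readable size. No step beyond the scatter can be drawn from them, and with every measured value at the limit the likeliest outcome for compound 4 is again a limit. The step from compound 3 is expected to be a step that the limit leaves unreadable from compound 3 to compound 4. Compound 4 is estimated at 300 ug/mL, within the range 150 ug/mL to 800 ug/mL.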

Compound 4, half-maximal inhibitory concentration: > 200 ug/mL
Compound 4 was reported as a limit; the forecaster's own chance of this, stated with the estimate: 80%; the middle value lies beyond the limit too.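

Compound 4 sits at the same limit as compound 1, compound 2 and compound 3 in this assay, so none of the steps from those three compounds to compound 4 can be read: the limit of > 200 ug/mL in this assay, at which 4 of the 4 values shown sit.

The compounds shown leave open whether any aryl group on the shared core gives a numerical value in this read-out, and how large a step between such groups would be.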